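Lengthening the hydroxyalkyl side chain on a thiophene amide

A few compounds are considered here, and "the series" means these few. Any claim that something is new, unique, unknown or untested is made for them only; others in the source may bear on it.

Measured so far in an assay on cells for positive allosteric modulation of Cystic fibrosis transmembrane conductance regulator variant F508del (Homo sapiens), with stated times of 10 min and 7 s, in the presence of a further agent that is not named here; on this read-out lower numbers stand for an effect already at smaller amounts and higher numbers for an effect only at larger amounts of compound:
- compound 1 `CC1(C)Cc2c(sc(NC(=O)Cc3ccn[nH]3)c2C(N)=O)C(C)(C)O1`: 136 nM
- compound 2 `CC1(C)Cc2c(sc(NC(=O)C3CNC(=O)C3)c2C(N)=O)C(C)(C)O1`: > 10000 nM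
- compound 3 `CC1(C)Cc2c(sc(NC(=O)C(C)(C)CO)c2C(N)=O)C(C)(C)O1`: 75 nM

The three compounds share one core and differ only in the group attached to the carbonyl carbon of the amide. Compound 2 gave no number, only the limit (the limit of > 10000 nM in this assay, at which 1 of the 3 values shown sits). Compound 3 and compound 1 lie close together, as shown by a 1.8-fold lower number from compound 1 to compound 3 (0.26 log units; within the scatter). Against compound 2 the gap is wide: an at least 130-fold lower number from compound 2 to compound 3 (2.12 log units; beyond the scatter).

Compound 4 `CC(C)(C)CC(O)C(=O)Nc1sc2c(c1C(N)=O)CC(C)(C)OC2(C)C` keeps the core and changes the amide substituent again: a group of 7 heavy atoms (6 carbon, 1 oxygen; no ring) in place of a group of 5 heavy atoms (4 carbon, 1 oxygen; no ring), on a carbonyl carbon. Both groups carry one hydrogen-bond donor and one acceptor and have no ring. The nearest measured comparison is the step from the (1H-pyrazol-5-yl)methyl to the hydroxy-bearing group of compound 3, which stayed within the scatter; the large step involving compound 2 concerns a ring and bears less on this change. A step of little size is therefore expected in this assay, neither clearly up nor down: a 1.5-fold higher number from compound 3 to compound 4 (0.17 log units; within the scatter). Compound 4 is estimated at 110 nM, with a range from 30 nM to 450 nM.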

Compound 4, half-maximal effective concentration: 0.54 nM
Beside the measured number, compound 4's estimate is 200-fold (2.31 log units) above it; the whole stated range lies above it.
By their numbers in this assay, from the lowest: compound 4; then compounds 3 and 1 (each within the scatter of the next). At a limit, above all of these: compound 2.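

The steps of a 140-fold lower number from compound 3 to compound 4 (2.14 log units; beyond the scatter) and a 250-fold lower number from compound 1 to compound 4 (2.40 log units; beyond the scatter) and an at least 18000-fold lower number from compound 2 to compound 4 (4.26 log units; beyond the scatter) show that the group on this carbonyl carbon can reach far lower numbers than compound 1 and compound 3 suggested. The change from compound 3 to compound 4 is small by count, with the same hydrogen-bond donor and acceptor counts and no ring on either side, yet it still shifts the number in this assay strongly. Compound 2 stands at a limit and not at a number, so its step is only a bound: the limit of > 10000 nM in this assay, at which 1 of the 4 values shown sits.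

Nothing shown here says why compound 4 gives so low a number.

On these data alone, whether an amine in place of the hydroxy group, or a longer chain on the carbonyl carbon, would keep numbers this low stays open.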